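Swapping acetyl for dimethylamino on a cyanomethyl pyrazole

The source may report more compounds than this note shows. Statements on the series, on what has been measured and on what is new or still open speak of the compounds shown alone.

Three analogues share one core. Compound 1 `COc1cc(C)cc(-c2c(-c3ccnc(-c4ccc(C(C)=O)cc4)c3)cnn2CC#N)c1` gives -48% in a functional assay on MDA-MB-468 cells (Homo sapiens) for cytotoxicity, read by sulforhodamine B assay, with a stated time of 48 h, tested at 1 uM (on this read-out higher numbers stand for a weaker effect at the one concentration tested and lower numbers for a stronger effect), the highest of the three numbers, though within the scatter of both others. Within the data shown here, compound 2 `COc1cc(C)cc(-c2nn(CC#N)cc2-c2ccnc(-c3ccc(N(C)C)cc3)c2)c1` gives -55% and compound 3 `Cc1cc(O)cc(-c2nn(CC#N)cc2-c2ccnc(-c3ccc(N(C)C)cc3)c2)c1` gives -50%; the only one-place step between measured compounds, a number 5 percentage points higher from compound 2 to compound 3 (within the scatter), concerns a methoxy-to-hydroxyl change and so does not bear on the move to compound 4 `COc1cc(C)cc(-c2c(-c3ccnc(-c4ccc(N(C)C)cc4)c3)cnn2CC#N)c1`, which differs from compound 1 by dimethylamino in place of acetyl on an aromatic carbon. Among the measured compounds shown here, compound 2 also carries a dimethylamino group and its number sits within the scatter of compound 1, but no measured pair isolates this swap. The expectation for compound 4 is therefore no step beyond the scatter, a number 2 percentage points lower from compound 1 to compound 4 (within the scatter), giving an estimate of -50% with a range from -65% to -35%.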

Compound 4, a percentage reported as activity, at one concentration (the size of the read-out at that concentration, not a potency): -57%
The estimate for compound 4 lay 7 percentage points above the measured number, within the range that was stated.
By their numbers in this assay, from the lowest: compounds 4, 2, 3 and 1 (each within the scatter of the next).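

In this assay, among these compounds, the change from 4-acetylphenyl to 4-(dimethylamino)phenyl is the first measured pair to isolate this swap, and it gives a number 9 percentage points lower from compound 1 to compound 4 (within the scatter) on the aromatic carbon para to a large group. At the one concentration tested, this place therefore takes either group without a step beyond the scatter. No measurement here explains this result.

Going by these compounds, whether a primary amine, a carboxylic acid or a longer chain at the same place would stay within the scatter remains open. The pair also leaves open whether the swap reads the same on other cell lines.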